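The compounds below may be only part of what the source reports. "The series", "measured", "known", "first", "only" and "open" are said of these compounds alone.

Measured in an ADME assay on Raji cells (Homo sapiens) for cytotoxicity, read by luminescence, with a stated time of 72 h; a higher number here means that more compound is needed for the effect, a lower number that less compound is needed:
Compound 1 `CCOC(=O)c1c(-c2cccc(C(F)(F)F)c2)[nH]c2cc(OC)ccc2c1=O`: > 21500 nM
Compound 2 `CCOC(=O)c1c(-c2cccc(F)c2)[nH]c2cc(OC)ccc2c1=O`: > 21500 nM
Compound 3 `CCOC(=O)c1c(-c2cccc(Br)c2)[nH]c2cc(OC)ccc2c1=O`: > 21500 nM

Each of these entries is a limit of the assay and not a number. Compound 3 therefore has no exact position, and the record for the series is the limit of > 21500 nM in this assay, at which 3 of the 3 values shown sit.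

Compound 4 `CCOC(=O)c1c(-c2cccc(S(C)(=O)=O)c2)[nH]c2cc(OC)ccc2c1=O` follows from compound 3 by one change, methylsulfonyl in place of bromo on an aromatic carbon.

The measured steps that bear on this change are the other exchanges of one group on an aromatic carbon: a step that the two limits leave unreadable from compound 1 to compound 2, a step that the two limits leave unreadable from compound 1 to compound 3 and a step that the two limits leave unreadable from compound 2 to compound 3. None of the three has a size that can be read, so they show no direction. A step beyond the scatter in this assay is therefore not expected, though the limits leave this weakly supported. The expected change is a step that the limit leaves unreadable from compound 3 to compound 4. For compound 4 the estimated value is 30000 nM, with an expected range from 15000 nM to 60000 nM.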

Compound 4, half-maximal effective concentration: > 21500 nM
Compound 4: no number, only a limit (the forecaster's own chance of this, stated with the estimate: 90%); the middle value lies beyond the limit too.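

Within the data shown here, compound 4 also gives only a limit of the assay, so no step from compound 1, compound 2 or compound 3 to compound 4 can be read in this assay. The record for the series stays at one value: the limit of > 21500 nM in this assay, at which 4 of the 4 values shown sit. The compounds shown leave open whether exchanging this group on the aromatic carbon changes the concentration needed at all.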